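The compounds below may be only part of what the source reports. "The series", "measured", "known", "first", "only" and "open" are said of these compounds alone.

Measured in a functional assay on OVCAR-8 cells (Homo sapiens) for inhibition, read by sulforhodamine B assay, tested at 10 uM; a higher number here means more inhibition at the concentration tested (going by the name of the read-out), a lower number less inhibition:
compound 1 `COc1cc2oc(-c3cccc(NC(=O)c4ccc(Br)cc4)c3)cc(=O)c2c(OC)c1OC` gives 52.9%.
compound 2 `COc1cc2oc(-c3cccc(C(=O)Nc4ccc(Cl)cc4)c3)cc(=O)c2c(OC)c1OC` gives 56.9%.
compound 3 `COc1cc2oc(-c3cccc(C(=O)Nc4ccc(Cl)cc4)c3)cc(=O)c2c(O)c1OC` gives 83.7%.

Among these three numbers compound 3 stands highest. Its nearest neighbour is compound 2, separated by a number 26.8 percentage points higher from compound 2 to compound 3 (beyond the scatter), a step beyond the scatter; compound 1 lies further away again, also beyond the scatter. Compound 4 `COc1cc2oc(-c3cccc(C(=O)Nc4ccc(C#N)cc4)c3)cc(=O)c2c(O)c1OC` differs from compound 3 in one place: cyano in place of chloro on an aromatic carbon. Cut one bond further out, the exchange reads 4-chlorophenyl to 4-cyanophenyl.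

Neither measured step touches this group. The step of a number 4 percentage points higher from compound 1 to compound 2 (within the scatter) rearranges the link between the two aryl rings and lies within the scatter, while a number 26.8 percentage points higher from compound 2 to compound 3 (beyond the scatter) concerns an oxygen on the core and is modest but beyond the scatter. Nothing in the measured set therefore speaks to swapping chloro for cyano on the outer ring, and the expectation rests on the value of compound 3 alone. For compound 4 the expected step in this assay is a number 5.7 percentage points lower from compound 3 to compound 4 (within the scatter), that is, none that clears the scatter. Compound 4 is thus estimated at 78%, with a range from 55% to 95%, the width reflecting the absence of any bearing step.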

Compound 4, a percentage reported as inhibition, at one concentration (the size of the read-out at that concentration, not a potency): 70.9%
The estimate for compound 4 lay 7.1 percentage points above the measured number; the range from low to high includes it.
By their numbers in this assay, from the lowest: compounds 1 and 2 (each within the scatter of the next); then compound 4; then compound 3.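

For the compounds shown here, this is the first reading of the outer ring, at the place para to a large group, and the substituent there is not neutral in this assay: with everything else held as in compound 3, the exchange of chloro for cyano gives a number 12.8 percentage points lower from compound 3 to compound 4 (beyond the scatter) and leaves compound 4 at 70.9%. Going by these compounds alone, the earlier steps spoke only to the link between the two aryl rings and to an oxygen on the core, so this step shows for the first time that the outer ring's substituent can move the number by more than the scatter, though only modestly. The exchange brings one more heavy atom and one hydrogen-bond acceptor by count, but no measurement here ties the lower number to either of these or to anything else.

The compounds shown leave open whether the number with chloro at this place is higher than with groups in general or only the number with cyano is lower, since only these two have been compared and neither an unsubstituted ring nor an amine, a carboxylic acid or a methoxy group appears there. They also leave open whether the same exchange would give a step of similar size on the fully methylated core of compound 2, where the hydroxyl group of compound 3 is absent.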